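The compounds below may be only part of what the source reports. "The series", "measured", "known", "first", "only" and "open" are said of these compounds alone.

In a functional assay for antagonist activity at Alpha-1A adrenergic receptor (Oryctolagus cuniculus) (on this read-out higher numbers stand for weaker binding and lower numbers for tighter binding), compound 1 `CN(C)C(=O)c1cccnc1NCCCN1CCN(c2ccccc2O)CC1` gives 5.01 nM and compound 2 `CN(C)C(=O)c1cccnc1NCCCN1CCN(c2ccccc2-c2ccccc2)CC1` gives 1.26 nM. For the measured compounds named here, compound 2 thus holds the lowest of the two numbers so far, and the one measured step, a 4.0-fold lower number from compound 1 to compound 2 (0.60 log units; beyond the scatter), separates it from compound 1. Compound 3 `Cc1ccccc1N1CCN(CCCNc2ncccc2C(=O)N(C)C)CC1` differs from compound 2 by methyl in place of phenyl on an aromatic carbon, at the same aromatic carbon that the known step altered. That step swapped hydroxy for phenyl; here a ring leaves and a single carbon enters, so part of the gain is expected to be given back, probably a small step upward. Compound 3 is estimated at 2.5 nM, within 1 nM to 6.3 nM. The expected step is a 2.0-fold higher number from compound 2 to compound 3 (0.30 log units; within the scatter), possibly within the scatter.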

Compound 3, dissociation constant: 2 nM
The estimate for compound 3 lay 1.3-fold (0.10 log units) above the measured number; low and high end bracket the measured number.
By their numbers in this assay, from the lowest: compounds 2 and 3 (each within the scatter of the next); then compound 1.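

In this assay, at this aromatic carbon ortho to a large group, methyl and phenyl cannot be told apart: a 1.6-fold higher number from compound 2 to compound 3 (0.20 log units; within the scatter). A single carbon therefore suffices to hold the number of compound 2 without the aromatic ring, and methyl still shows a 2.5-fold lower number from compound 1 to compound 3 (0.40 log units; beyond the scatter), so both carbon groups stand apart from hydroxy. No measurement here accounts for these steps. Going by these compounds, whether methoxy or chlorine at this carbon tracks methyl or hydroxy remains open. So does whether ethyl or a longer chain would stay level with methyl and phenyl.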